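The source may report more compounds than this note shows. Statements on the series, on what has been measured and on what is new or still open speak of the compounds shown alone.

Measured compounds in the series:
compound 1 `CCc1nc2c(C)cc(C)nc2n1Cc1ccc(OC(C(=O)O)c2ccccc2)c(Cl)c1` — 720 nM
compound 2 `C=CCc1cc(Cn2c(CC)nc3c(C)cc(C)nc32)ccc1OC(C(=O)O)c1ccccc1` — 270 nM

In an assay on Midbrain with Type-2 angiotensin II receptor (Rattus norvegicus) as the target (on this read-out lower numbers stand for stronger inhibition and higher numbers for weaker inhibition), compound 1 gives 720 nM and compound 2 gives 270 nM. Among the compounds with values here, compound 2 thus holds the lowest of the two numbers; its nearest neighbour is compound 1, and the only measured step, a 2.7-fold lower number from compound 1 to compound 2 (0.43 log units; beyond the scatter), separates them.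

Compound 3 `CCc1nc2c(C)cc(C)nc2n1Cc1ccc(OC(C(=O)O)c2ccccc2)c(C(C)C)c1` is not yet measured. Its change from compound 2 is isopropyl in place of allyl on an aromatic carbon. Within the data shown here, the single measured step bears on it only loosely: it swapped chloro for allyl at this same aromatic carbon and moved the number modestly, whereas here one three-carbon group gives way to another at that position. Among the measured compounds shown here, no measured pair shows allyl against isopropyl. The expected step of a 1.1-fold higher number from compound 2 to compound 3 (0.05 log units; within the scatter) is therefore no more than within the scatter, with no direction favoured. Compound 3 is estimated at 300 nM, with a range of 120 nM to 800 nM.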

Compound 3, half-maximal inhibitory concentration: 3300 nM
The estimate for compound 3 lay 11-fold (1.04 log units) below the measured number; measured number above the stated range.
By their numbers in this assay, from the lowest: compound 2; then compound 1; then compound 3.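

In this assay this aromatic carbon, ortho to a carboxy(phenyl)methoxy group, proves sensitive even to an exchange between two groups of 3 heavy atoms (3 carbon), with no ring and no hydrogen-bond donors or acceptors: a 12-fold higher number from compound 2 to compound 3 (1.09 log units; beyond the scatter), a far larger move than the earlier one from chloro to allyl. The comparison with chloro gives a 4.6-fold higher number from compound 1 to compound 3 (0.66 log units; beyond the scatter), so compound 1 falls between the two three-carbon compounds and heavy-atom count alone does not order these three groups. Nothing available here explains the gap between allyl and isopropyl.

The compounds shown leave open whether a straight n-propyl chain would track allyl or isopropyl, which would separate the double bond from the branching. Also open, going by these compounds, is how a methoxy group or an amine would rank at this carbon.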